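Methoxy in place of chloro, with the series at a limit

The compounds below may be only part of what the source reports. "The series", "measured", "known", "first", "only" and "open" are said of these compounds alone.

Of the compounds shown here, two have been read so far in an ADME assay on MT4 cells (Homo sapiens) for cytotoxicity, read by cell counting (a lower number here means a stronger inhibitor, a higher number a weaker inhibitor), and neither gives a number. Compound 1 (`Nc1nc(O)c2ncn(CSC(CO)CO)c2n1`) gives > 150000 nM as a limit of the assay. Compound 2 (`Nc1nc(Cl)c2ncn(CCC(CO)CO)c2n1`) gives > 150000 nM as a limit of the assay as well. Both measured compounds therefore stand at one limit (the limit of > 150000 nM in this assay, at which 2 of the 2 values shown sit) and no numerical reading exists yet to compare them.

Compound 3 (`COc1nc(N)nc2c1ncn2CCC(CO)CO`) has methoxy in place of chloro on an aromatic carbon and is otherwise the same as compound 2. Within the data shown here, no step between measured compounds is available to size this change, so the only anchor is compound 2 at > 150000 nM which is a limit. In this assay the estimate for a number no higher from compound 2 to compound 3 (the limit leaves the size open) is no shift beyond the scatter, with no direction expected. For compound 3 the expected value is 150000 nM with an estimated range from 60000 nM to 300000 nM and a limit of the assay is the likeliest expected outcome.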

Compound 3, half-maximal inhibitory concentration: > 150000 nM
Compound 3: only a limit was reported (the forecaster's own chance of this, stated with the estimate: 80%); the middle value lies on the limit itself.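

In this assay compound 3 gives > 150000 nM, which is a limit of the assay. With compound 2 also at a limit, no step between compound 2 and compound 3 can be read: the limit of > 150000 nM in this assay, at which 3 of the 3 values shown sit.

The compounds shown leave open whether methoxy in place of chloro on an aromatic carbon changes the reading in this assay at all.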